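Triazine piperazine amides: cytotoxicity notes, methoxy to chloro

The compounds below may be only part of what the source reports. "The series", "measured", "known", "first", "only" and "open" are said of these compounds alone.

Measured so far:
- compound 1, `COc1ccccc1N1CCN(CC(=O)N2CCN(c3nnc(-c4ccc(C)cc4)c(-c4ccc(C)cc4)n3)CC2)CC1`: 133000 nM
- compound 2, `Cc1ccc(-c2nnc(N3CCN(C(=O)CN4CCN(c5ccccc5Cl)CC4)CC3)nc2-c2ccc(C)cc2)cc1`: > 859000 nM, a limit of the assay
- compound 3, `COc1ccc(-c2nnc(N3CCN(C(=O)CN4CCN(c5ccc(OC)cc5)CC4)CC3)nc2-c2ccc(OC)cc2)cc1`: > 821000 nM, a limit of the assay

Three compounds carry the same piperazine amide linkage to the triazine core and have been run in an ADME assay on NIH3T3 cells (Mus musculus) for cytotoxicity, read by MTT assay, with a stated time of 24 h; a lower number here means a stronger inhibitor, a higher number a weaker inhibitor. For the measured compounds named here, compound 1 is the only one with a number: compound 1 gives 133000 nM. For compound 2 only a limit is known, > 859000 nM. The change from compound 1 to compound 2 is chloro in place of methoxy on an aromatic carbon, and the step it made is an at least 6.4-fold higher number from compound 1 to compound 2 (0.81 log units; beyond the scatter); the limit is the limit of > 859000 nM in this assay, at which 1 of the 3 values shown sits.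

Compound 3 also sits at a limit, > 821000 nM, namely (the limit of > 821000 nM in this assay, at which 1 of the 3 values shown sits). How the core of compound 3 differs from the core of compound 1 is not broken down here.

Compound 4, `COc1ccc(-c2nnc(N3CCN(C(=O)CN4CCN(c5ccc(Cl)cc5)CC4)CC3)nc2-c2ccc(OC)cc2)cc1`, is not yet measured. From compound 3 it differs by chloro in place of methoxy on an aromatic carbon. This is the same kind of change as that from compound 1 to compound 2, but the place is not the same: there the chloro stands ortho to a large group, here para to a large group.

Expectation: because compound 3 already reaches > 821000 nM, compound 4 is expected to sit at a limit as well, with a step of roughly a step that the limit leaves unreadable from compound 3 to compound 4. The estimate for compound 4 is 1000000 nM, within 400000 nM to 3000000 nM.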

Compound 4, half-maximal inhibitory concentration: > 814000 nM
Compound 4 gave a limit, no number; the forecaster's own chance of this, stated with the estimate: 80%; the middle value lies beyond the limit too.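

In this assay compound 4 gives > 814000 nM, a limit of the assay. For the compounds shown here, compound 3 is likewise known only as a limit, so no step between compound 3 and compound 4 can be read. The compounds shown leave open how large the change from 4-methoxyphenyl to 4-chlorophenyl is in this series.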